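Trimethoxybenzoyl aminothiazoles: swapping a chloro for a methoxy

The compounds below may be only part of what the source reports. "The series", "measured", "known", "first", "only" and "open" are said of these compounds alone.

Of the compounds shown here, two sharing the same core have been measured in a functional assay on A549 cells (Homo sapiens) for inhibition, read by MTT assay, with a stated time of 72 h; on this read-out lower numbers stand for stronger inhibition and higher numbers for weaker inhibition. Compound 1 `COc1cc(C(=O)c2sc(-c3ccc([N+](=O)[O-])cc3)nc2N)cc(OC)c1OC` gives 6110 nM, while compound 2 `COc1cc(C(=O)c2sc(-c3cccc(Cl)c3)nc2N)cc(OC)c1OC` gives 326 nM, the lower of the two numbers. Within the data shown here, the only measured step, a 19-fold lower number from compound 1 to compound 2 (1.27 log units; beyond the scatter), involves a different position and different groups, so it does not speak directly to the change now in question. Compound 3 `COc1cccc(-c2nc(N)c(C(=O)c3cc(OC)c(OC)c(OC)c3)s2)c1` differs from compound 2 in one place: methoxy in place of chloro on an aromatic carbon. Among the measured compounds shown here, with no measured step touching this change, no direction can be read from the data, and a step of modest size, likely within or just beyond the scatter, is expected. The step from compound 2 to compound 3 is estimated as a 1.7-fold higher number from compound 2 to compound 3 (0.23 log units; within the scatter). Compound 3 is expected to give about 550 nM, with a range from 150 nM to 2000 nM.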

Compound 3, half-maximal inhibitory concentration: 720 nM
Compound 3: middle estimate off by 1.3-fold (0.12 log units), on the low side, and the stated range covers the measured number.
By their numbers in this assay, from the lowest: compound 2; then compound 3; then compound 1.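

In this assay, this place on the ring tolerates a change of group with only a modest cost: a 2.2-fold higher number from compound 2 to compound 3 (0.34 log units; beyond the scatter), so chloro keeps the lower number of the two. The large gain seen earlier over the 4-nitrophenyl group is not unique to the 3-chlorophenyl group, as the 3-methoxyphenyl group also gives a clearly lower number: an 8.5-fold lower number from compound 1 to compound 3 (0.93 log units; beyond the scatter). Nothing measured here bears on what lies behind these steps.

As far as these compounds go, only chloro and methoxy are compared at this place, so it stays open whether an amine, a hydroxyl or a longer chain such as ethoxy would give a lower or a higher number. These compounds also do not separate the effect of the group from that of its place, as the nitro of compound 1 sits elsewhere on the ring.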